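The compounds below may be only part of what the source reports. "The series", "measured", "known", "first", "only" and "open" are said of these compounds alone.

Measured compounds:
Compound 1, `Cc1cc2cc(OCC(=O)O)ccc2n1Cc1ccc(O)c(C(C)C)c1`: 16.3 nM
Compound 2, `Cc1cn(Cc2ccc(O)c(C(C)C)c2)c2ccc(OCC(=O)O)cc12`: 7.74 nM
Compound 3, `Cc1cc(OCC(=O)O)cc2cc(C)n(Cc3ccc(O)c(C(C)C)c3)c12`: 2.05 nM

In an assay on HeLa cells for displacement of a labelled ligand from thyroid hormone receptor alpha (Homo sapiens) (a higher number here means a weaker inhibitor, a lower number a stronger inhibitor), compound 2 gives 7.74 nM, the second highest of the three numbers. Its nearest neighbour is compound 1, which gives 16.3 nM, a number beyond the scatter above it; furthest away is compound 3, which gives 2.05 nM, beyond the scatter below it.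

Compound 4, `Cc1cn(Cc2ccc(O)c(C(C)C)c2)c2c(Cl)cc(OCC(=O)O)cc12`, has not yet been measured. It differs from compound 2 in one place: chloro in place of hydrogen on an aromatic carbon. The chlorine enters on the six-membered ring of the shared core, ortho to a fused ring and meta to a carboxymethoxy group.

Within the data shown here, one measured step bears on this change. From compound 1 to compound 3 a methyl replaces a hydrogen on an aromatic carbon of that same six-membered ring, ortho to a fused ring and meta to a carboxymethoxy group, and the result was an 8.0-fold lower number from compound 1 to compound 3 (0.90 log units; beyond the scatter). A chloro is a small group of one heavy atom entering the same kind of place, so a lower number in this assay is expected for compound 4, though the step is estimated to be smaller than the methyl step: a 2.6-fold lower number from compound 2 to compound 4 (0.41 log units; beyond the scatter). Compound 4 is therefore expected to give about 3 nM, with a range from 1 nM to 10 nM.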

Compound 4, inhibition constant: 0.51 nM
Beside the measured number, compound 4's estimate is 5.9-fold (0.77 log units) above it; measured number outside the range, below it.
By their numbers in this assay, from the lowest: compound 4; then compound 3; then compound 2; then compound 1.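

In this assay, chloro in place of hydrogen on this aromatic carbon, ortho to a fused ring and meta to a carboxymethoxy group, gives a 15-fold lower number from compound 2 to compound 4 (1.18 log units; beyond the scatter), a step printed as large. Set beside an 8.0-fold lower number from compound 1 to compound 3 (0.90 log units; beyond the scatter), a step printed as modest, it shows that the number falls with two different single groups at this kind of place, a methyl on one core and a chloro on the other, so the lowering is not confined to the methyl group or to one arrangement of the shared core. Nothing given here accounts for the size of the chloro step.

Still open, from the compounds shown here alone, is whether the two groups themselves differ at this place, since the methyl and the chloro steps start from different cores, and only a methyl on the core of compound 2 or a chloro on the core of compound 1 would set them side by side. Also open, going by these compounds, is how far the trend extends to other groups at the same carbon, such as a bromo, a methoxy or an amine.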